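Aryl sulfide variation on the shared diamine core

A few compounds are considered here, and "the series" means these few. Any claim that something is new, unique, unknown or untested is made for them only; others in the source may bear on it.

The shared core is carried by compound 2 `Nc1cc(N)c2nc(-c3ccccc3)c(Sc3ccc(F)cc3)nc2c1` and compound 1 `CCOC(=O)[C@H](CCC(=O)O)NC(=O)c1ccc(Sc2nc3cc(N)cc(N)c3nc2-c2ccccc2)cc1`. In a functional assay on OVCAR-5 cells (Homo sapiens) for inhibition, read by sulforhodamine B assay, with a stated time of 48 h (a higher number here means a weaker inhibitor of growth, a lower number a stronger inhibitor of growth), compound 2 gives 45700 nM. For compound 1 the result in this assay is a limit rather than a number, < 100000 nM, which is the point recorded in the limit of < 100000 nM in this assay, at which 1 of the 2 values shown sits. Compound 2 thus holds the only number shown, and no step between measured compounds is available to calibrate a change on the sulfur. Compound 3 `Nc1cc(N)c2nc(-c3ccccc3)c(Sc3ccc(Cl)c(Cl)c3)nc2c1` is not yet measured in this assay; it differs from compound 2 by 3,4-dichlorophenyl in place of 4-fluorophenyl on a sulfur. Going by the values given here, with no measured step to lean on, the expected step in this assay is a modest gain, around the edge of the usual scatter, a 2.3-fold lower number from compound 2 to compound 3 (0.36 log units; beyond the scatter). Compound 3 is accordingly estimated at 20000 nM in this assay, with a range from 5000 nM to 80000 nM.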

Compound 3, concentration for total growth inhibition: 58900 nM
Compound 3: the middle estimate sits 2.9-fold (0.47 log units) below what was measured; the range from low to high includes it.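

Going by these compounds alone, the first step that can be read at this position is a 1.3-fold higher number from compound 2 to compound 3 (0.11 log units; within the scatter), for 3,4-dichlorophenyl in place of 4-fluorophenyl on a sulfur in this assay. Exchanging the single fluorine for two chlorines on the phenyl ring therefore does not separate compound 2 from compound 3 in this read-out. Compound 1 remains a limit and not a number, and its steps to the other two compounds cannot be read: the limit of < 100000 nM in this assay, at which 1 of the 3 values shown sits.

Going by these compounds, whether any group on this sulfur can move the concentration for total growth inhibition beyond the scatter remains open. A nitrile or methoxy group on the phenyl ring, or a simple alkyl chain in place of the ring, would test this position beyond the halogen-bearing phenyl groups of compound 2 and compound 3.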